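The source may report more compounds than this note shows. Statements on the series, on what has been measured and on what is new or still open speak of the compounds shown alone.

Measured so far:
compound 1 `Oc1cccc(-c2cc(-c3ccccc3C(F)(F)F)cc(-c3ccccc3O)n2)c1` — 7250 nM
compound 2 `Oc1cccc(-c2cc(-c3cccc(C(F)(F)F)c3)cc(-c3ccccc3O)n2)c1` — 13000 nM

Among the measured compounds shown here, in a functional assay on DU-145 cells (Homo sapiens) for inhibition (a lower number here means a stronger inhibitor, a higher number a weaker inhibitor), compound 2 gives 13000 nM, a number within the scatter of that of compound 1; the single measured step is a 1.8-fold higher number from compound 1 to compound 2 (0.25 log units; within the scatter). Compound 3 `Oc1ccc(-c2cc(-c3cccc(C(F)(F)F)c3)cc(-c3cccc(O)c3)n2)cc1` differs from compound 2 by 4-hydroxyphenyl in place of 2-hydroxyphenyl on an aromatic carbon. For the measured compounds named here, the one measured step concerns the trifluoromethylphenyl group, not the hydroxyphenyl group, so no measured step bears on this change, and the data hold nothing on moving the hydroxyl. The account therefore expects no step beyond the scatter, a 1.1-fold lower number from compound 2 to compound 3 (0.03 log units; within the scatter). Compound 3 is estimated at 12000 nM, with a range from 4000 nM to 36000 nM.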

Compound 3, half-maximal inhibitory concentration: 11100 nM
The estimate for compound 3 lay 1.1-fold (0.03 log units) above the measured number, and the stated range covers the measured number.
By their numbers in this assay, from the lowest: compounds 1, 3 and 2 (each within the scatter of the next).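

Among the compounds shown here, the first measured change at this hydroxyphenyl group, next to the ring nitrogen, gives a 1.2-fold lower number from compound 2 to compound 3 (0.07 log units; within the scatter) in this assay. With the trifluoromethylphenyl and 3-hydroxyphenyl groups held constant, this assay does not distinguish 2-hydroxyphenyl from 4-hydroxyphenyl at this place. Nothing here accounts for this result. From the compounds shown here alone, it remains open whether replacing the hydroxyl on this ring with an amine or a carboxylic acid would give a step beyond the scatter. Also open, going by these compounds, is whether the same hydroxyl change would behave alike alongside 2-(trifluoromethyl)phenyl.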